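The compounds below may be only part of what the source reports. "The series", "measured", "known", "first", "only" and "open" are said of these compounds alone.

Measured in a functional assay on the whole organism for antagonist activity, with Mus musculus as the target; a higher number here means that more compound is needed for the effect, a lower number that less compound is needed:
Compound 1 `CCCCCC(=O)NCC(=O)N(C)c1ccc(Cl)cc1C(=O)c1ccccc1Cl`: 1.9 mg/kg
Compound 2 `CC(C)C(=O)NCC(=O)N(C)c1ccc(Cl)cc1C(=O)c1ccccc1Cl`: 6 mg/kg
Compound 3 `CN(C(=O)CNC(=O)CN1CCN(c2ccccc2)CC1)c1ccc(Cl)cc1C(=O)c1ccccc1Cl`: 75 mg/kg

Of these three, compound 3 carries the highest number in this assay. Compound 4 `CCCCC(=O)NCC(=O)N(C)c1ccc(Cl)cc1C(=O)c1ccccc1Cl` differs from it by one change: propyl in place of 4-phenylpiperazin-1-yl on a saturated chain carbon bound to a carbonyl carbon. Going by the values given here, two measured steps bear on this. Putting 4-phenylpiperazin-1-yl in place of butyl gave a large rise, a 39-fold higher number from compound 1 to compound 3 (1.60 log units; beyond the scatter). Between the two open-chain compounds the difference is modest, a 3.2-fold higher number from compound 1 to compound 2 (0.50 log units; beyond the scatter). Removing the 4-phenylpiperazin-1-yl is therefore expected to reverse most of that large rise, giving a large step to a lower number and a value in the region of compound 1 and compound 2. The expected change is a 21-fold lower number from compound 3 to compound 4 (1.33 log units; beyond the scatter). Compound 4 is estimated at 3.5 mg/kg, with an expected range of 1.5 mg/kg to 8 mg/kg.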

Compound 4, dose for half-maximal effect: 1.3 mg/kg
Beside the measured number, compound 4's estimate is 2.7-fold (0.43 log units) above it; the whole stated range lies above it.
By their numbers in this assay, from the lowest: compounds 4 and 1 (each within the scatter of the next); then compound 2; then compound 3.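

In this assay propyl in place of 4-phenylpiperazin-1-yl gives a 58-fold lower number from compound 3 to compound 4 (1.76 log units; beyond the scatter) and so places this open-chain group at the low end of the series. The two straight chains cannot be told apart, with a 1.5-fold lower number from compound 1 to compound 4 (0.16 log units; within the scatter), while butyl in place of isopropyl on a carbonyl carbon gives a 4.6-fold lower number from compound 2 to compound 4 (0.66 log units; beyond the scatter) and leaves isopropyl apart from them. Nothing available here explains these differences. Going by these compounds, it remains open whether a longer chain would keep the number as low. On these data alone, it is also open whether an unsubstituted piperazine or a simple amine at this position would raise it as 4-phenylpiperazin-1-yl does.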